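Working notes on cytotoxicity across three measured analogues

This account rests on a few compounds, and the source may have more. Where it says the series, first, only, none or still open, it means among the compounds named here.

compound 1 `COc1ccc(-n2cc(CNCCN3CCN(C)CC3)c(-c3ccccc3C)n2)cc1`: > 20000 nM
compound 2 `CCN(CC)CCCNCc1cn(-c2ccc(F)cc2F)nc1-c1ccccc1C`: > 20000 nM
compound 3 `COc1ccc(-c2nn(-c3ccc(F)cc3F)cc2CNCCN2CCN(C)CC2)cc1`: > 20000 nM

In an ADME assay on Huh-7 cells (Homo sapiens) for cytotoxicity (on this read-out higher numbers stand for lower toxicity in this test and lower numbers for higher toxicity in this test), compound 1 gives > 20000 nM, which is a limit of the assay rather than a number. Compound 2 likewise reaches only the limit in this assay. Compound 3 also sits at the limit in this assay. Every measured value lies at the same limit (the limit of > 20000 nM in this assay, at which 3 of the 3 values shown sit), so compound 1 cannot be placed above or below the others; it stands where all of them stand.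

Compound 4 `Cc1ccccc1-c1nn(Cc2ccccc2)cc1CNCCN1CCN(C)CC1` has not been measured. It differs from compound 1 by benzyl in place of 4-methoxyphenyl on an aromatic nitrogen. Among the compounds with values here, no step between measured compounds is available; the only guide is that all three values sit at the limit (the limit of > 20000 nM in this assay, at which 3 of the 3 values shown sit). The step that the limit leaves unreadable from compound 1 to compound 4 is expected to be none beyond the scatter. Compound 4 is expected at 25000 nM, with a range from 10000 nM to 60000 nM.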

Compound 4, half-maximal cytotoxic concentration: > 20000 nM
Compound 4 gave a limit, no number (the forecaster's own chance of this, stated with the estimate: 75%); the middle value does not contradict the limit.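

Compound 1 and compound 4 both stand at a limit, so no step between them can be read: the limit of > 20000 nM in this assay, at which 4 of the 4 values shown sit.

The compounds shown leave open whether benzyl and 4-methoxyphenyl differ at all in this assay.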